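A few compounds are considered here, and "the series" means these few. Any claim that something is new, unique, unknown or untested is made for them only; others in the source may bear on it.

Measured so far:
- compound 1 `CCSc1nnc(Cc2ccccc2Oc2ccccc2)[nH]1`: 142%
- compound 2 `CCCSc1nnc(Cc2ccccc2Oc2ccccc2)[nH]1`: 139%
- compound 3 `CCSc1nnc(Cc2ccc(Cl)cc2Oc2ccccc2F)[nH]1`: 144%

Compound 1, compound 2 and compound 3 were each tested in a functional assay on the whole organism (strain NMRI) with Mus musculus as the target, with a stated time of 60 min, at a dose of 10 mg/kg by the intraperitoneal route; on this read-out lower numbers stand for a weaker effect and higher numbers for a stronger effect at the one dose given. Compound 4 `CCCSc1nnc(Cc2ccc(Cl)cc2Oc2ccccc2F)[nH]1` is not yet measured there.

Compound 2 differs from compound 1 by methyl in place of hydrogen on a saturated chain carbon, two bonds along the chain from a sulfur; the step was a number 3 percentage points lower from compound 1 to compound 2 (within the scatter). Compound 4 differs from compound 3 by methyl in place of hydrogen on a saturated chain carbon, two bonds along the chain from a sulfur, the same change at the same place. The difference between the core of compound 1 and the core of compound 3 is not broken down here; their two values in this assay lie within the scatter of each other.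

For compound 4 a step of a number 3 percentage points lower from compound 3 to compound 4 (within the scatter) is expected in this assay, resting on the earlier step of a number 3 percentage points lower from compound 1 to compound 2 (within the scatter) for the same change. Compound 4 is therefore estimated at 141% in this assay, with a range of 126% to 156%.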

Compound 4, a percentage reported as activity, at one dose (the size of the read-out at that dose, not a potency): 127%
Estimate against measurement, compound 4: 14 percentage points above, and the stated range covers the measured number.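

On the core of compound 3, the change from ethylsulfanyl to propylsulfanyl gives a number 17 percentage points lower from compound 3 to compound 4 (beyond the scatter) in this assay, while on the core of compound 1 the same change gives a number 3 percentage points lower from compound 1 to compound 2 (within the scatter). Set side by side, the two steps cannot be told apart: the same change on two cores in this assay, a number 3 percentage points lower (within the scatter) from compound 1 to compound 2 and a number 17 percentage points lower (beyond the scatter) from compound 3 to compound 4, 14 percentage points apart, within the scatter of two such steps. The change therefore carries over between these two cores as far as this one pair of steps can show, but the pair does not fix the size of the step or show that it holds on any other core.

Still open, going by these compounds, is how a longer chain such as butyl on the sulfur would read in this assay. On these data alone, an amine or a carboxylic acid at the end of that chain is equally open.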